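The compounds below may be only part of what the source reports. "The series", "measured", "known", "first", "only" and "open" are said of these compounds alone.

Measured compounds:
Compound 1 `NCCCCN(C[C@H]1Cc2ncccc2CN1)[C@H]1CCCc2cccnc21` gives 64%
Compound 2 `NC/C=C/CN(C[C@H]1Cc2ncccc2CN1)[C@H]1CCCc2cccnc21` gives 11%
Compound 3 `CN(CCCCN(C[C@H]1Cc2ncccc2CN1)[C@H]1CCCc2cccnc21)C1CCOCC1` gives 64%

In an ADME assay on microsomes from liver (Rattus norvegicus) for metabolic stability, using NADPH, with a stated time of 10 min (a lower number here means that less of the compound is left, a higher number that more of the compound is left), compound 2 stands lowest of the three numbers, with both other compounds well beyond the scatter above it. Compound 4 `c1cnc2c(c1)CN[C@@H](CN(CCCCNC1COC1)[C@H]1CCCc3cccnc31)C2` differs from compound 2 in one place: a group of 8 heavy atoms (6 carbon, 1 nitrogen, 1 oxygen; one four-membered non-aromatic ring with 1 hetero atom) in place of a group of 4 heavy atoms (3 carbon, 1 nitrogen; no ring), on a saturated chain carbon bound to an amine nitrogen. Within the data shown here, two measured steps bear on this change. The step of a number 53 percentage points lower from compound 1 to compound 2 (beyond the scatter) was large, and the step of a number 53 percentage points higher from compound 2 to compound 3 (beyond the scatter) was equally large in the opposite direction, where a saturated chain carrying a ring replaced the same 3-aminoprop-1-en-1-yl group. The change to compound 4 likewise removes that group and brings in a saturated chain with a ring, so a large rise beyond the scatter is expected, with compound 4 estimated at 55% (range 30% to 75%), a step of a number 44 percentage points higher from compound 2 to compound 4 (beyond the scatter).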

Compound 4, percent of the compound remaining: 27%
Beside the measured number, compound 4's estimate is 28 percentage points above it; the measured number lies below the stated range.
By their numbers in this assay, from the lowest: compound 2; then compound 4; then compounds 1 and 3 (each within the scatter of the next).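

In this assay, a saturated chain carrying a ring does not by itself bring a high number, since the change gives only a number 16 percentage points higher from compound 2 to compound 4 (beyond the scatter). Oxetan-3-yl in place of hydrogen on an amine nitrogen gives a number 37 percentage points lower from compound 1 to compound 4 (beyond the scatter), and (oxetan-3-yl)amino in place of methyl(oxan-4-yl)amino gives a number 37 percentage points lower from compound 3 to compound 4 (beyond the scatter), so the group carried by the saturated chain matters, which compound 1 and compound 3 alone did not show. Nothing available explains this result. Ring size and the methyl group change together between compound 3 and compound 4, so their shares stay unseparated. Going by these compounds, it also remains open how a cyclobutyl group on that nitrogen would compare.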